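From pentylcarbonyl ester to methyl ether

The source may report more compounds than this note shows. Statements on the series, on what has been measured and on what is new or still open speak of the compounds shown alone.

Measured so far in a functional assay on MCF7 cells (Homo sapiens) for inhibition, with a stated time of 48 h, tested at 50 uM; a lower number here means less inhibition of growth, a higher number more inhibition of growth at the concentration tested:
- compound 1 `C=C[C@@](C)(/C=C/c1ccc(OC(=O)CCC)cc1)CCC=C(C)C` gives 20%
- compound 2 `C=C[C@@](C)(/C=C/c1ccc(OC(=O)CCCCC)cc1)CCC=C(C)C` gives 18%

Within the data shown here, compound 2 (18%) stands within the scatter of compound 1 (20%), the only other measured compound. Compound 3 `C=C[C@@](C)(/C=C/c1ccc(OC)cc1)CCC=C(C)C` is unmeasured and carries methyl in place of pentylcarbonyl on an oxygen on an aromatic ring. Among the measured compounds shown here, the sole measured step (a number 2 percentage points lower from compound 1 to compound 2 (within the scatter)) lies within the scatter, but it keeps the carbonyl that this change removes, so it bears only loosely on compound 3. No step beyond the scatter is expected in this assay on this evidence. The estimated step (a number 6 percentage points higher from compound 2 to compound 3 (within the scatter)) is small and upward. Compound 3 is expected at 24% (estimated range 10% to 42%).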

Compound 3, percent growth inhibition at one concentration: 18%
Estimate against measurement, compound 3: 6 percentage points above; the range from low to high includes it.
By their numbers in this assay, from the lowest: compounds 2, 3 and 1 (each within the scatter of the next).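

In this assay, methyl in place of pentylcarbonyl on an oxygen on an aromatic ring gives no change at the digits printed from compound 2 to compound 3 (within the scatter), and methyl in place of propylcarbonyl gives a number 2 percentage points lower from compound 1 to compound 3 (within the scatter). The earlier pair both kept the carbonyl; these steps show that the ether without it stands level with both esters at this position. No supporting data bear on why these numbers stay together.

Open, on these data alone, is what a hydroxyl, an amine or a carboxylic acid at this place would give. Also open, as far as these compounds go, is whether any group on this oxygen moves the number beyond the scatter.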